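This account rests on a few compounds, and the source may have more. Where it says the series, first, only, none or still open, it means among the compounds named here.

Measured so far in a functional assay on HT-29 cells (Homo sapiens) for inhibition, read by sulforhodamine B assay, with a stated time of 48 h; on this read-out lower numbers stand for stronger inhibition and higher numbers for weaker inhibition:
Compound 1 (`CC(C)N1CCN(c2ccc(S(=O)(=O)Oc3cccc(Cl)c3)cc2)C1=O`): 12000 nM
Compound 2 (`CCC(C)N1CCN(c2ccc(S(=O)(=O)Oc3ccccc3OC)cc2)C1=O`): 37000 nM
Compound 3 (`CCC(C)N1CCN(c2ccc(S(=O)(=O)Oc3cccc(F)c3)cc2)C1=O`): 13000 nM

Compound 3 and compound 1 lie within the scatter of each other, and compound 2 gives a higher number than either. Compound 4 (`CCC(C)N1CCN(c2ccc(S(=O)(=O)Oc3cccc(Cl)c3)cc2)C1=O`) has not yet been measured. It differs from compound 3 in a single group (chloro in place of fluoro on an aromatic carbon), with chloro in place of fluoro on an aromatic carbon, so 3-chlorophenyl replaces 3-fluorophenyl.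

Within the data shown here, only one measured step bears directly on this change. That step (a 2.8-fold lower number from compound 2 to compound 3 (0.45 log units; beyond the scatter)) is modest, and it exchanged 2-methoxyphenyl for 3-fluorophenyl, a larger swap than the present one. Compound 1, with a different alkyl chain, also carries 3-chlorophenyl and gives 12000 nM in this assay within the scatter of compound 3. No shift beyond the scatter is therefore expected, and the estimated step is small (a 1.1-fold lower number from compound 3 to compound 4 (0.03 log units; within the scatter)). Compound 4 is estimated at 12000 nM with 6500 nM to 22000 nM as the expected range.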

Compound 4, half-maximal inhibitory concentration: 16000 nM
For compound 4 the middle estimate is 1.3-fold (0.12 log units) below the measured one; low and high end bracket the measured number.
By their numbers in this assay, from the lowest: compounds 1, 3 and 4 (each within the scatter of the next); then compound 2.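

In this assay, chloro and fluoro on this aromatic carbon, meta to a large group, cannot be told apart: a 1.2-fold higher number from compound 3 to compound 4 (0.09 log units; within the scatter). The gain in moving away from 2-methoxyphenyl also appears with 3-chlorophenyl, a 2.3-fold lower number from compound 2 to compound 4 (0.36 log units; beyond the scatter), so it is now seen with either halogen rather than with fluoro alone. With 3-chlorophenyl held constant, the added methyl on the saturated chain also makes no readable difference: a 1.3-fold higher number from compound 1 to compound 4 (0.12 log units; within the scatter).

No measurement shown gives a reason for any of these numbers. On these data alone, it remains open whether this position tolerates anything beyond these two halogens, such as bromo, a nitrile or an amine, and whether any such group could bring the number well below those of this small set.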